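Working notes: from compound 2 to compound 3

The source may report more compounds than this note shows. Statements on the series, on what has been measured and on what is new or still open speak of the compounds shown alone.

In an ADME assay on L02 cells (Homo sapiens) for antiproliferative activity, read by MTT assay, with a stated time of 48 h (a lower number here means a stronger inhibitor, a higher number a weaker inhibitor), compound 1 `CCn1c(C(=O)NCCCN(C)C)ccc1C(CC)(CC)c1ccc(OCCC(O)(CC)CC)c(C)c1` gives 2420 nM and compound 2 `CCn1c(C(=O)N(C)CC(=O)O)ccc1C(CC)(CC)c1ccc(OCCC(O)(CC)CC)c(C)c1` gives 2150 nM, so compound 2 stands level with compound 1. Among the compounds with values here, the only measured step, a 1.1-fold lower number from compound 1 to compound 2 (0.05 log units; within the scatter), changes the group on the same carbonyl carbon and lies within the scatter. Compound 3 `CCn1c(C(=O)NC(C)C(=O)O)ccc1C(CC)(CC)c1ccc(OCCC(O)(CC)CC)c(C)c1` carries (1-carboxyethyl)amino in place of (carboxymethyl)(methyl)amino on that carbonyl carbon ((1-carboxyethyl)amino in place of (carboxymethyl)(methyl)amino on a carbonyl carbon). With that one small step as the guide, no shift beyond the scatter is expected in this assay. The expected step is a 1.0-fold higher number from compound 2 to compound 3 (0.01 log units; within the scatter). Compound 3 is estimated at 2200 nM, within a range of 1200 nM to 4000 nM.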

Compound 3, half-maximal inhibitory concentration: 4040 nM
Estimate against measurement, compound 3: 1.8-fold (0.26 log units) below; the measured number lies above the stated range.
By their numbers in this assay, from the lowest: compounds 2, 1 and 3 (each within the scatter of the next).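

In this assay, placing (1-carboxyethyl)amino in place of (carboxymethyl)(methyl)amino on a carbonyl carbon rearranges the same atoms and adds the amide hydrogen, yet gives a 1.9-fold higher number from compound 2 to compound 3 (0.27 log units; within the scatter). Likewise, 1-carboxyethyl in place of 3-(dimethylamino)propyl on an amide-type nitrogen gives a 1.7-fold higher number from compound 1 to compound 3 (0.22 log units; within the scatter), so all three groups at this position lie within the scatter of one another. Nothing available bears on the reason for these numbers. As far as these compounds go, it remains open whether a ring amine such as morpholine, or a longer carboxylic acid chain, on this carbonyl carbon would give a step beyond the scatter.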